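Thiophene in Place of Dimethoxyphenyl on a Shared Core

The source may report more compounds than this note shows. Statements on the series, on what has been measured and on what is new or still open speak of the compounds shown alone.

Measured so far in a functional assay on HL-60 cells (Homo sapiens) for cytotoxicity, read by MTT assay, with a stated time of 72 h; on this read-out lower numbers stand for stronger inhibition and higher numbers for weaker inhibition:
Compound 1 `C=C(Br)C(=O)Nc1cccc(-c2cn3nc(-c4ccc(F)cc4)sc3n2)c1` gives 530 nM.
Compound 2 `C=C(Br)C(=O)Nc1cccc(-c2cn3nc(-c4ccc(OC)c(OC)c4)sc3n2)c1` gives 210 nM.

Going by the values given here, compound 2 stands at the lowest of the two numbers; the only measured step is a 2.5-fold lower number from compound 1 to compound 2 (0.40 log units; beyond the scatter), a modest change from one aryl group to another on the same aromatic carbon of the shared core.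

Compound 3 `C=C(Br)C(=O)Nc1cccc(-c2cn3nc(-c4cccs4)sc3n2)c1` has not yet been measured. Among the compounds with values here, its single difference from compound 2 is thiophen-2-yl in place of 3,4-dimethoxyphenyl on an aromatic carbon. Within the data shown here, the one measured step bears on this change only loosely, since it concerns a different exchange at the same position; it shows that the group there can shift the number by a modest amount, in either direction. With no closer comparison available, compound 3 is expected to sit between the two measured values, most likely a step of a 2.1-fold higher number from compound 2 to compound 3 (0.33 log units; beyond the scatter). Compound 3 is therefore estimated at 450 nM, with a range from 150 nM to 1400 nM.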

Compound 3, half-maximal inhibitory concentration: 380 nM
Estimate against measurement, compound 3: 1.2-fold (0.07 log units) above; low and high end bracket the measured number.
By their numbers in this assay, from the lowest: compounds 2, 3 and 1 (each within the scatter of the next, the first and the last beyond it).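

In this assay thiophen-2-yl in place of 3,4-dimethoxyphenyl gives a 1.8-fold higher number from compound 2 to compound 3 (0.26 log units; within the scatter) while thiophen-2-yl in place of 4-fluorophenyl gives a 1.4-fold lower number from compound 1 to compound 3 (0.14 log units; within the scatter) and so compound 3 cannot be told apart from either of the other two. The earlier pair showed only six-membered aromatic rings on this carbon; now a five-membered aromatic ring with sulfur, with fewer heavy atoms than 3,4-dimethoxyphenyl, leaves the number in the same region. Nothing measured here offers an explanation for this result. The compounds shown leave open whether a ring is needed on this carbon at all, since an amine or a longer alkyl chain there could move the number much further. They also leave open what a single methoxy group or a pyridine ring would do.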